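Swapping the acyl group on a shared amide core

A few compounds are considered here, and "the series" means these few. Any claim that something is new, unique, unknown or untested is made for them only; others in the source may bear on it.

Measured so far:
compound 1, `O=C(Nc1ccccc1O)C1CCc2ccccc2N1C(=O)c1ccccc1Cl`: 44900 nM
compound 2, `CCCCCCCCC(=O)N1c2ccccc2CCC1C(=O)Nc1ccccc1O`: 38400 nM

Compound 2 and compound 1 differ in one place only, the group on the carbonyl carbon attached to the ring nitrogen. In a functional assay on HCT-15 cells (Homo sapiens) for cytotoxicity, read by sulforhodamine B assay, with a stated time of 72 h (a lower number here means a stronger inhibitor of growth, a higher number a weaker inhibitor of growth), compound 2 gives 38400 nM, and compound 1 gives 44900 nM. The step of a 1.2-fold lower number from compound 1 to compound 2 (0.07 log units; within the scatter) shows that these two numbers lie within the scatter of each other, so on the numbers shown compound 2 does not stand apart from compound 1.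

Compound 3, `O=C(Nc1ccccc1O)C1CCc2ccccc2N1C(=O)c1cccc(Cl)c1`, is not yet measured. The change from compound 2 is 3-chlorophenyl in place of octyl on a carbonyl carbon. Among the compounds with values here, the only measured step that bears on this change is the one in the opposite direction, from a chlorophenyl group to octyl, a 1.2-fold lower number from compound 1 to compound 2 (0.07 log units; within the scatter), which was within the scatter. Putting a chlorophenyl group back in place of octyl is therefore expected to give no step beyond the scatter in this assay; where the chlorine sits on the ring has no measured comparison here. The expected step is a 1.1-fold higher number from compound 2 to compound 3 (0.04 log units; within the scatter), and compound 3 is estimated at 42000 nM, with a range from 15000 nM to 120000 nM.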

Compound 3, concentration for 50% growth inhibition: 23100 nM
The estimate for compound 3 lay 1.8-fold (0.26 log units) above the measured number; the measured number falls inside the stated range.
By their numbers in this assay, from the lowest: compounds 3, 2 and 1 (each within the scatter of the next).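

In this assay, 3-chlorophenyl in place of octyl on the carbonyl carbon gives a 1.7-fold lower number from compound 2 to compound 3 (0.22 log units; within the scatter), and 3-chlorophenyl in place of 2-chlorophenyl gives a 1.9-fold lower number from compound 1 to compound 3 (0.29 log units; within the scatter). Within the data shown here, this adds the first comparison of two chlorophenyl groups that differ only in where the chlorine sits, and that comparison, like the comparison of each chlorophenyl group with the octyl chain, does not separate the compounds: compound 1, compound 2 and compound 3 cannot be told apart in this assay, even though a ringless chain and two aromatic rings have occupied this position on the carbonyl carbon. No separate measurement accompanies these numbers that could account for them.

The compounds shown leave open whether any group at this position can produce a step beyond the scatter, for instance an amine, a carboxylic acid, a shorter chain or a phenyl group with no chlorine. They also leave open whether a change elsewhere on the shared core would move the number further than these acyl swaps have done.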